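The source may report more compounds than this note shows. Statements on the series, on what has been measured and on what is new or still open speak of the compounds shown alone.

Two esters built on the same core have been tested in a functional assay on K562 cells (Homo sapiens) for antiproliferative activity, read by sulforhodamine B assay, with a stated time of 48 h, tested at 50 uM; a lower number here means less inhibition, a higher number more inhibition at the concentration tested (going by the name of the read-out). Compound 1 `COc1ccc(C(=O)Oc2cc3c(cc2C)[C@@H](C(C)C)CC=C3C)cc1` carries a 4-methoxyphenyl ring on its ester carbonyl, and in this assay compound 1 gives 46.5%. Compound 2 `Cc1cc2c(C(C)C)ccc(C)c2cc1OC(=O)c1ccc([N+](=O)[O-])cc1` carries a 4-nitrophenyl ring in that position, and in this assay compound 2 gives 100%. Within the data shown here, the gap between the two lies beyond the usual scatter, so compound 1 stands as the lower of the two numbers known so far.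

Compound 3 `CC1=CC[C@H](C(C)C)c2cc(C)c(OC(=O)c3cccc([N+](=O)[O-])c3)cc21` has not yet been measured. It differs from compound 1 in one place: 3-nitrophenyl in place of 4-methoxyphenyl on a carbonyl carbon. Among the measured compounds shown here, no measured pair shows this exact exchange, so the size of the step can only be anticipated, not read off. Because compound 2, which also carries a nitrophenyl ring, gives 100% while compound 1 gives 46.5%, a rise beyond the scatter is expected for this change as well. Compound 3 is therefore expected to give about 80% in this assay, within a range from 45% to 100%. The expected step of a number 33.5 percentage points higher from compound 1 to compound 3 (beyond the scatter) would thus be an upward one.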

Compound 3, a percentage reported as inhibition, at one concentration (the size of the read-out at that concentration, not a potency): 15.9%
Beside the measured number, compound 3's estimate is 64.1 percentage points above it, and the stated range ends above it.
By their numbers in this assay, from the lowest: compound 3; then compound 1; then compound 2.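

Among these compounds, this is the first pair that differs in one place only, so the effect of the ring on the carbonyl carbon can be read directly. In this assay, putting 3-nitrophenyl in place of 4-methoxyphenyl gives a number 30.6 percentage points lower from compound 1 to compound 3 (beyond the scatter), which shows that inhibition at the tested concentration depends strongly on which ring sits at this position of the ester. No measurement shown here accounts for the drop, so the result records the size and direction of the change but not the reason for it.

Two things changed together in this exchange, the group on the ring and where that group is named on it, and this single pair cannot separate them; a 3-methoxyphenyl or a 4-nitrophenyl ring on the core of compound 1 would begin to do so. From the compounds shown here alone, it also remains open how this position responds to other groups, such as a ring bearing an amine or a carboxylic acid, or a longer alkyl chain in place of the ring.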